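The source may report more compounds than this note shows. Statements on the series, on what has been measured and on what is new or still open speak of the compounds shown alone.

Measured in a functional assay on MCF7 cells (Homo sapiens) for cytotoxicity, read by MTT assay, with a stated time of 72 h; on this read-out lower numbers stand for stronger inhibition and higher numbers for weaker inhibition: compound 1 `O=C(CSC(=S)N[C@H]1CCOC1=O)Nc1ccc(Cl)cc1` gives 50300 nM. Compound 2 `Cc1ccc(NC(=O)CSC(=S)N[C@H]2CCOC2=O)cc1` gives 33500 nM. Compound 3 `O=C(CSC(=S)N[C@H]1CCOC1=O)Nc1ccc(O)cc1` gives only > 128000 nM, a limit of the assay rather than a number.

Compound 3 thus stands at the weak end of the three, sitting at the limit of > 128000 nM in this assay, at which 1 of the 3 values shown sits. Compound 4 `CCCCc1ccc(NC(=O)CSC(=S)N[C@H]2CCOC2=O)cc1` differs from it by butyl in place of hydroxy on an aromatic carbon. Among the compounds with values here, the steps that bear on this change are those leading into the hydroxy compound: an at least 2.5-fold higher number from compound 1 to compound 3 (0.40 log units; beyond the scatter) and an at least 3.8-fold higher number from compound 2 to compound 3 (0.58 log units; beyond the scatter), both beyond the scatter. Replacing the hydroxy with butyl is therefore expected to reverse that loss and return the number to the region of the chloro and methyl analogues. The expected step is an at least 4.2-fold lower number from compound 3 to compound 4 (0.63 log units; beyond the scatter). Compound 4 is estimated at 30000 nM, within 10000 nM to 100000 nM.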

Compound 4, half-maximal inhibitory concentration: 40200 nM
For compound 4 the middle estimate is 1.3-fold (0.13 log units) below the measured one; the range from low to high includes it.
By their numbers in this assay, from the lowest: compounds 2, 4 and 1 (each within the scatter of the next). At a limit, above all of these: compound 3.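

With a 1.2-fold higher number from compound 2 to compound 4 (0.08 log units; within the scatter) and a 1.3-fold lower number from compound 1 to compound 4 (0.10 log units; within the scatter) both within the scatter, this assay does not separate butyl from methyl or chloro at this position. Against hydroxy, an at least 3.1-fold lower number from compound 3 to compound 4 (0.50 log units; beyond the scatter) marks compound 3 as the only one of the four that stands apart, and the larger butyl group gives no measurable penalty here. Compound 3 stands at a limit of the assay, not at a number: the limit of > 128000 nM in this assay, at which 1 of the 4 values shown sits.

As far as these compounds go, whether the loss belongs to hydroxy alone stays open, and an amine or a carboxylic acid at this position would test that. A chain longer than butyl would show how far this tolerance extends.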